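A few compounds are considered here, and "the series" means these few. Any claim that something is new, unique, unknown or untested is made for them only; others in the source may bear on it.

Measured compounds:
Compound 1, `O=C(O)/C=C/c1ccc(Cn2cccn2)cc1OCCc1ccc2ccccc2c1`, gives 3300 nM in an assay on CHO cells for displacement of a labelled ligand from prostaglandin E2 receptor EP2 subtype (Mus musculus), read by scintillation counting; on this read-out higher numbers stand for weaker inhibition and lower numbers for stronger inhibition.
Compound 2, `COc1ccc(/C=C/C(=O)O)c(OCCC2(C)CCc3c(C)c(O)c(C)c(C)c3O2)c1`, gives 6800 nM in this assay.
Compound 3, `O=C(O)/C=C/c1ccc(Cn2ccnc2)cc1OCCCOc1ccccc1`, gives > 10000 nM in this assay, which is a limit of the assay and not a number.

Among the measured compounds shown here, of the three measured compounds, compound 3 is the one without a numerical value: it sits at the limit of > 10000 nM in this assay, at which 1 of the 3 values shown sits, so its true inhibition constant is known only to lie beyond the range the assay reports. Compound 1 and compound 2 carry numbers that are both weak.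

Compound 4, `O=C(O)/C=C/c1ccc(Cn2ccnc2)cc1OCCCCOc1ccccc1`, is the next compound to be measured in this assay. It differs from compound 3 in one place: phenoxymethyl in place of phenoxy on a saturated chain carbon, three bonds along the chain from an oxygen on an aromatic ring. That is, phenoxymethyl in place of phenoxy on a saturated chain carbon, three bonds along the chain from an oxygen on an aromatic ring.

For the measured compounds named here, no step between two measured compounds that differ in a single place is available here, so there is no measured precedent for this kind of change. The expectation is therefore conservative: a step of no clear size beyond the scatter in either direction, with compound 4 most likely remaining near the limit where compound 3 stands. Compound 4 is estimated at 12000 nM, with a range from 4000 nM to 40000 nM, which corresponds to an expected step that the limit leaves unreadable from compound 3 to compound 4.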

Compound 4, inhibition constant: > 10000 nM
Compound 4: no number, only a limit (the forecaster's own chance of this, stated with the estimate: 60%); the middle value is on the limit's open side.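

In this assay, among the compounds shown here, compound 4 gives > 10000 nM, which is a limit of the assay and not a number, and compound 3 also stands at a limit, so no step between compound 3 and compound 4 can be read. The compounds shown leave open whether phenoxymethyl in place of phenoxy changes the inhibition constant at all.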